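The source may report more compounds than this note shows. Statements on the series, on what has been measured and on what is new or still open speak of the compounds shown alone.

Measured so far:
- compound 1, `O=C(O)/C=C/c1ccc(/C(=C(\c2ccccc2)C(F)F)c2ccc3[nH]ncc3c2)cc1`: 14 nM
- compound 2, `O=C(O)/C=C/c1ccc(/C(=C(\c2ccccc2)C2CC2)c2ccc3[nH]ncc3c2)cc1`: 13 nM
- compound 3, `CC/C(=C(/c1ccc(/C=C/C(=O)O)cc1)c1cc2cn[nH]c2cn1)c1ccccc1`: 442 nM

All three were tested in a functional assay on MCF7 cells (Homo sapiens) for cytotoxicity, read by CellTiter-Glo, with a stated time of 5 days; on this read-out higher numbers stand for weaker inhibition and lower numbers for stronger inhibition. Compound 3 gives the highest number of the three, that is the weakest inhibition; compound 1 lies a long way below it, and compound 2 a little further still, both gaps well beyond the scatter. Going by the values given here, the only single-place step measured so far runs between compounds 1 and 2: a 1.1-fold lower number from compound 1 to compound 2 (0.03 log units; within the scatter), a change at the same chain position as the one considered here but of quite another kind.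

Compound 4, `CC/C(=C(/c1ccc(/C=C/C(=O)O)cc1)c1ccc2[nH]nc(Cl)c2c1)c1ccccc1`, differs from compound 3 in one place: a group of 10 heavy atoms (7 carbon, 2 nitrogen, 1 chlorine; one five-membered aromatic ring with 2 hetero atoms, one six-membered aromatic ring of carbon only) in place of a group of 9 heavy atoms (6 carbon, 3 nitrogen; one five-membered aromatic ring with 2 hetero atoms, one six-membered aromatic ring with 1 hetero atom), on a double-bonded chain carbon bound to an aromatic carbon and a double-bonded chain carbon. Among the compounds with values here, no measured step covers this kind of change, so it cannot be read off directly. What the numbers do show is that the two compounds whose two-ring group lacks a ring nitrogen in the six-membered ring, compounds 1 and 2, sit far below compound 3; compound 4 also lacks that ring nitrogen, though it differs from compounds 1 and 2 elsewhere too. A step downward beyond the scatter is therefore expected: an 11-fold lower number from compound 3 to compound 4 (1.04 log units; beyond the scatter). Compound 4 is estimated at 40 nM, within 10 nM to 160 nM.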

Compound 4, half-maximal inhibitory concentration: 284 nM
For compound 4 the middle estimate is 7.1-fold (0.85 log units) below the measured one; the whole stated range lies below it.
By their numbers in this assay, from the lowest: compounds 2 and 1 (each within the scatter of the next); then compounds 4 and 3 (each within the scatter of the next).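

In this assay the exchange of the two-ring group for 3-chloro-1H-indazol-5-yl gives a 1.6-fold lower number from compound 3 to compound 4 (0.19 log units; within the scatter) and so leaves the pair within the scatter of each other. This shows that, on a double-bonded chain carbon bound to an aromatic carbon and a double-bonded chain carbon, a group without the nitrogen in its six-membered ring can still give a number that cannot be told apart from that of compound 3, so the absence of that nitrogen does not by itself set compounds 1 and 2 apart, though both differ from compound 4 in more than one place. No measurement available here accounts for this result.

The change removes a ring nitrogen and adds a chlorine in a single step, so this pair cannot show what each does alone, and the two could even offset one another. Also open, as far as these compounds go, is how the same two-ring group would behave with no chlorine, or with a bromine atom or a methyl group in the chlorine's place.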